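Amide variation on the methylindolyl-pyrimidine anilide series

The source may report more compounds than this note shows. Statements on the series, on what has been measured and on what is new or still open speak of the compounds shown alone.

Measured so far in a functional assay on A549 cells (Homo sapiens) for antiproliferative activity, read by MTT assay, with a stated time of 72 h; on this read-out higher numbers stand for weaker inhibition and lower numbers for stronger inhibition:
Compound 1, `COc1cc(F)c(NC(=O)c2ccnc(Cl)c2)cc1Nc1nccc(-c2cn(C)c3ccccc23)n1`: 6890 nM
Compound 2, `COc1cc(F)c(NC(=O)c2ccncc2OC)cc1Nc1nccc(-c2cn(C)c3ccccc23)n1`: 3430 nM
Compound 3, `COc1cc(N(C)C)c(NC(=O)c2ccnc(Cl)c2)cc1Nc1nccc(-c2cn(C)c3ccccc23)n1`: 3430 nM

Compound 1 and compound 2 share the whole molecule apart from the amide aryl group. The change is 3-methoxypyridin-4-yl in place of 2-chloropyridin-4-yl on a carbonyl carbon. On this assay it gave a 2.0-fold lower number from compound 1 to compound 2 (0.30 log units; within the scatter), a step that stays within the usual scatter of repeated measurements, so the two numbers cannot be ordered with confidence.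

Compound 3 differs from compound 1 elsewhere: dimethylamino in place of fluoro on an aromatic carbon. That change gave a 2.0-fold lower number from compound 1 to compound 3 (0.30 log units; within the scatter), again within the scatter. Compound 3 and compound 2 give the same number at the digits reported.

Compound 4, `COc1cc(N(C)C)c(NC(=O)c2ccncc2OC)cc1Nc1nccc(-c2cn(C)c3ccccc23)n1`, has not yet been measured. It carries the core of compound 3 and the amide aryl group of compound 2. Relative to compound 3 the change is 3-methoxypyridin-4-yl in place of 2-chloropyridin-4-yl on a carbonyl carbon. The place is the same as in the step from compound 1 to compound 2, a carbonyl carbon whose other neighbour is an amide-type nitrogen, so this is the same change made on a second core.

Among the compounds with values here, for compound 4 in this assay, a step of a 1.8-fold lower number from compound 3 to compound 4 (0.26 log units; within the scatter) is expected, set beside a 2.0-fold lower number from compound 1 to compound 2 (0.30 log units; within the scatter), since only that one earlier example of the change is available and it was small. Within the data shown here, compound 4 is therefore estimated at 1900 nM, with a plausible range from 800 nM to 4500 nM; the single precedent and its size within the scatter leave the direction uncertain.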

Compound 4, half-maximal inhibitory concentration: 3030 nM
Compound 4: the middle estimate sits 1.6-fold (0.20 log units) below what was measured; the range from low to high includes it.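

On the second core, the change to 3-methoxypyridin-4-yl on the carbonyl carbon gives a 1.1-fold lower number from compound 3 to compound 4 (0.05 log units; within the scatter) in this assay and the two examples of this change cannot be told apart: the same change on two cores in this assay, a 2.0-fold lower number (0.30 log units; within the scatter) from compound 1 to compound 2 and a 1.1-fold lower number (0.05 log units; within the scatter) from compound 3 to compound 4, 1.8-fold (0.25 log units) apart, within the scatter of two such steps

The change to dimethylamino in place of fluoro reads the same way, giving a 1.1-fold lower number from compound 2 to compound 4 (0.05 log units; within the scatter) on the core that carries the 3-methoxypyridin-4-yl amide, and again the two examples cannot be told apart: the same change on two cores in this assay, a 2.0-fold lower number (0.30 log units; within the scatter) from compound 1 to compound 3 and a 1.1-fold lower number (0.05 log units; within the scatter) from compound 2 to compound 4, 1.8-fold (0.25 log units) apart, within the scatter of two such steps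

Across these four compounds, neither change shows any dependence on the core that carries it, but every step lies within the scatter, so this shows only that no core dependence can be detected, not that either change has a real effect that carries over from one core to the other.

The compounds shown leave open whether any replacement at either place can give a step beyond the scatter in this assay and so allow a real test of transfer between cores. A longer amine chain in place of dimethylamino, or a carboxylic acid on the amide aryl group in place of the methoxy or chloro substituent, would be among the open cases.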